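This account rests on a few compounds, and the source may have more. Where it says the series, first, only, none or still open, it means among the compounds named here.

Compound 1 `C=CC(=O)Nc1ccc(-c2nc(Cl)cc(Nc3ccc(C(=O)Nc4ccc(OC)cc4)cc3)n2)cc1` — "not determined" (no result reported) in a functional assay on Ramos cells (Homo sapiens) for antiproliferative activity, read by MTT assay, with a stated time of 48 h; on this read-out higher numbers stand for weaker inhibition and lower numbers for stronger inhibition.
Compound 2 `C=CC(=O)Nc1ccc(-c2nc(Cl)cc(Nc3ccc(C(=O)N4CCCC4)cc3)n2)cc1` — 10400 nM in this assay.

The two measured compounds share one core and differ only in the amide on the outer ring. On the numbers shown, compound 1 stands nowhere: in this assay compound 1 has no single value, so it gives no anchor. Compound 2, in this assay, gives 10400 nM, a weak result. Compound 3 `C=CC(=O)Nc1ccc(-c2nc(Cl)cc(Nc3ccc(C(=O)N(C)C)cc3)n2)cc1` is reached from compound 1 by dimethylamino in place of (4-methoxyphenyl)amino on a carbonyl carbon, in words dimethylamino in place of (4-methoxyphenyl)amino on a carbonyl carbon. Among the measured compounds shown here, no measured pair records this step, so its size and direction in this assay cannot be read from these data, and with compound 1 unmeasured there is no starting number to move from. Because compound 2 gives 10400 nM as a close analog, compound 3 is expected to come out near 10000 nM, with a range from 3000 nM to 40000 nM.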

Compound 3, half-maximal inhibitory concentration: > 50000 nM
Compound 3: a limit, no number (the forecaster's own chance of this, stated with the estimate: 25%); at least 5.0-fold (0.69 log units) between middle value and limit.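

Among the compounds shown here, the position on the carbonyl carbon turns out to be sensitive even to a small change in the amide, which the earlier compounds could not show. Putting dimethylamino in place of pyrrolidin-1-yl gives an at least 4.8-fold higher number from compound 2 to compound 3 (0.68 log units; beyond the scatter), so the ring-bearing compound 2, though weak at 10400 nM, still keeps a measurable effect in this assay. For compound 3 the reading is a limit and not a number, so the true size of the loss stays unknown: the limit of > 50000 nM in this assay, at which 1 of the 3 values shown sits.

For the compounds shown here, with no number for compound 1, no step involving its (4-methoxyphenyl)amino group can be read, so a large aromatic amide cannot be ranked against the small ones. Going by these compounds, whether a piperidin-1-yl or morpholin-4-yl group on the same carbonyl carbon would match compound 2 or improve on it also remains open.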